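The compounds below may be only part of what the source reports. "The series", "measured", "known", "first", "only" and "open" are said of these compounds alone.

In an ADME assay on microsomes from liver (Mus musculus) for metabolic stability (a lower number here means that the compound disappears faster, a higher number that the compound lasts longer), compound 1 `CC(C)C(Cc1ncc[nH]1)c1ccc(-c2ccc3cccc(F)c3c2)[nH]c1=O` is reported only as a limit, < 0.0667 h. Where compound 1 stands is thus known only from that limit (the limit of < 0.0667 h in this assay, at which 1 of the 3 values shown sits), and its true half-life may lie anywhere beneath it. Compound 2 `CC(C)C(Nc1nccs1)c1ccc(-c2ccc3cccc(F)c3c2)[nH]c1=O` gives 0.0733 h in this assay. Compound 3 `CC(C)C(c1cnc(N)s1)c1ccc(-c2ccc3cccc(F)c3c2)[nH]c1=O` gives 0.08 h in this assay. The measured steps away from compound 1 at the same carbon are an at least 1.0-fold higher number from compound 1 to compound 2 (0.04 log units; that floor lies within the scatter) and an at least 1.1-fold higher number from compound 1 to compound 3 (0.07 log units; that floor lies within the scatter), and between the two thiazole analogues the step is a 1.1-fold higher number from compound 2 to compound 3 (0.04 log units; within the scatter); all three values sit close to the low end of what this assay resolves. Compound 4 `CC(C)C(CC(N)=O)c1ccc(-c2ccc3cccc(F)c3c2)[nH]c1=O` differs from compound 1 by carbamoyl in place of 1H-imidazol-2-yl on a saturated chain carbon, two bonds along the chain from an aromatic carbon. For the measured compounds named here, no measured step exchanges the imidazolyl for a group without a ring, so the two steps from compound 1 to the thiazole analogues are the only guide, and both are floors inside the scatter. For compound 4 no step beyond the scatter is expected in this assay, an at least 1.0-fold higher number from compound 1 to compound 4 (0.02 log units; that floor lies within the scatter). Compound 4 is therefore estimated at 0.07 h, with a range from 0.03 h to 0.16 h, and a real chance that this assay again reports only a limit.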

Compound 4, half-life: < 0.0667 h
Compound 4: no number, only a limit; the forecaster's own chance of this, stated with the estimate: 40%; at least 1.0-fold (0.02 log units) between middle value and limit.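

In this assay compound 4 is reported only as a limit, < 0.0667 h, the same limit as compound 1, so the step connecting these two cannot be read. Against the thiazole analogues only floors inside the scatter are available, an at least 1.1-fold lower number from compound 3 to compound 4 (0.07 log units; that floor lies within the scatter) and an at least 1.0-fold lower number from compound 2 to compound 4 (0.04 log units; that floor lies within the scatter). Carbamoyl, with no ring, therefore does not lift the half-life off the floor any more than 1H-imidazol-2-yl does, and the low end of the assay now holds both a ring and a non-ring group at this carbon: the limit of < 0.0667 h in this assay, at which 2 of the 4 values shown sit.

As far as these compounds go, how far compound 1 and compound 4 lie under the limit stays unknown, so any difference in stability between them remains hidden. Also open, from the compounds shown here alone, is whether a carboxylic acid or a longer chain in place of carbamoyl on this saturated chain carbon would give a half-life clear of the limit.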